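A few compounds are considered here, and "the series" means these few. Any claim that something is new, unique, unknown or untested is made for them only; others in the source may bear on it.

In an ADME assay (liver) for metabolic stability, with Liver microsome (Homo sapiens) as the target, using microsomes (a higher number here means faster removal of the compound, a lower number slower removal), compound 3 `COC1CN(C(=O)c2cnc(Oc3cc(C(=O)Nc4cnccn4)cc4oc(C)cc34)cn2)C1` gives only a limit, < 9.2 mL/min/kg. Compound 1 `Cc1cnc(NC(=O)c2cc(Oc3cnc(C(=O)N(C)C)cn3)c3cc(C)oc3c2)cn1` likewise gives only a limit, < 8.5 mL/min/kg. Compound 2 `Cc1cc2c(Oc3cnc(C(=O)N4CC(C)(C)C4)cn3)cc(C(=O)Nc3cnccn3)cc2o1` gives a true number, 21.2 mL/min/kg. Compound 4 `Cc1cc2c(Oc3cnc(C(=O)N4CC5(COC5)C4)cn3)cc(C(=O)Nc3cnccn3)cc2o1` differs from compound 3 in one place: a group of 7 heavy atoms (5 carbon, 1 nitrogen, 1 oxygen; 2 four-membered non-aromatic rings with 1 hetero atom each) in place of a group of 6 heavy atoms (4 carbon, 1 nitrogen, 1 oxygen; one four-membered non-aromatic ring with 1 hetero atom), on a carbonyl carbon. Within the data shown here, the one measured step at this place is an at least 2.3-fold lower number from compound 2 to compound 3 (0.36 log units; beyond the scatter), and it is beyond the scatter. The groups leaving and entering in the new change each hold an oxygen, so this assay is not expected to shift much, and any rise should stay within the scatter. The estimated step is an at least 1.0-fold higher number from compound 3 to compound 4 (0.03 log units; that floor lies within the scatter). For compound 4 the expected clearance is 10 mL/min/kg, with an estimated range from 6.5 mL/min/kg to 18 mL/min/kg.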

Compound 4, clearance in the Liver microsome assay: 12.9 mL/min/kg
Compound 4: middle estimate off by 1.3-fold (0.11 log units), on the low side; the measured number falls inside the stated range.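

In the Liver microsome assay, the group with two four-membered rings gives an at least 1.4-fold higher number from compound 3 to compound 4 (0.14 log units; that floor lies within the scatter), and the limit on compound 3 leaves the true size of this step unknown. Against the group without oxygen, the step is a 1.6-fold lower number from compound 2 to compound 4 (0.22 log units; within the scatter), so the oxygen-holding group in compound 4 is not set apart from it. In a physicochemical assay for solubility, measured as kinetic solubility (a lower number here means a less soluble compound, a higher number a more soluble compound), compound 3 gives 158000 nM and compound 4 gives 43000 nM. In the physicochemical assay, the same change from compound 3 to compound 4 lowers the number: the measured solubility of compound 3, 158000 nM, and of compound 4, 43000 nM, a 3.7-fold lower number (0.57 log units; beyond the scatter)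

The compounds shown leave open how far compound 3 lies under its limit. They also leave open whether a hydroxyl or an amine in place of the methoxy of 3-methoxyazetidin-1-yl would keep clearance low and solubility high.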